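The source may report more compounds than this note shows. Statements on the series, on what has been measured and on what is new or still open speak of the compounds shown alone.

Measured compounds:
- Compound 1 `Cc1ccc(NS(=O)(=O)c2ccc3ccccc3c2)cc1Nc1nccc(-c2cccnc2)n1`: 9890 nM
- Compound 2 `COc1ccc(S(=O)(=O)Nc2ccc(C)c(Nc3nccc(-c4cc(OC)c(OC)c(OC)c4)n3)c2)cc1`: 9120 nM

In a functional assay on K562 cells (Homo sapiens) for cytotoxicity, read by MTT assay, with a stated time of 24 h (a lower number here means a stronger inhibitor, a higher number a weaker inhibitor), compound 1 gives 9890 nM, and compound 2 gives 9120 nM. Compound 2 has the lower of the two numbers, but the gap to compound 1 lies within the scatter of this assay, so the two values show nothing more than that both compounds sit in the same region.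

Compound 3 `COc1cc(-c2ccnc(Nc3cc(NS(=O)(=O)c4ccc5ccccc5c4)ccc3C)n2)cc(OC)c1OC` has not yet been measured. It differs from compound 2 in one place: naphthalen-2-yl in place of 4-methoxyphenyl on a sulfonyl sulfur. The same naphthalen-2-yl group already sits on the sulfonyl sulfur of compound 1, whose value is close to that of compound 2, while the rest of compound 3 matches compound 2.

For the measured compounds named here, with no measured step between two compounds that differ in only this one place, the size of the change cannot be read from the data. Because compound 1 gives 9890 nM and compound 2 gives 9120 nM, the expected step from compound 2 to compound 3 is a 1.0-fold higher number from compound 2 to compound 3 (0.02 log units; within the scatter), nothing beyond the scatter in either direction. Compound 3 is therefore estimated at 9500 nM, in the range from 4500 nM to 20000 nM.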

Compound 3, half-maximal inhibitory concentration: 9810 nM
Compound 3: middle estimate off by 1.0-fold (0.01 log units), on the low side; the measured number falls inside the stated range.
By their numbers in this assay, from the lowest: compounds 2, 3 and 1 (each within the scatter of the next).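

In this assay, naphthalen-2-yl in place of 4-methoxyphenyl on a sulfonyl sulfur gives a 1.1-fold higher number from compound 2 to compound 3 (0.03 log units; within the scatter), a direct reading of this change that the earlier pair of compounds, differing in more than one place, could not offer. Compound 3 also links to compound 1 through a second place, where 3,4,5-trimethoxyphenyl in place of pyridin-3-yl on an aromatic carbon gives a 1.0-fold lower number from compound 1 to compound 3 (0.00 log units; within the scatter), so among these three compounds neither change shifts the number beyond the scatter. No measurement at hand accounts for this result, which therefore stays without an explanation.

For the compounds shown here, the three compounds show only two aromatic groups on the sulfonyl sulfur, so it remains open whether a methyl group or a chain ending in an amine at that place would give a number beyond the scatter. From the compounds shown here alone, it is equally open whether a group such as a carboxylic acid or a morpholine, in place of 3,4,5-trimethoxyphenyl on the aromatic carbon, would leave the number in the same region.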